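Methoxy substitution on the phenyl group of compound 1

The source may report more compounds than this note shows. Statements on the series, on what has been measured and on what is new or still open speak of the compounds shown alone.

Measured so far in a functional assay on MCF7 cells (Homo sapiens) for cytotoxicity, read by MTT assay, with a stated time of 48 h; on this read-out higher numbers stand for weaker inhibition and lower numbers for stronger inhibition:
compound 1 `c1ccc(-c2nc(-c3c[nH]c4ccccc34)co2)cc1` — 131000 nM
compound 2 `Cc1nc(-c2c[nH]c3ccccc23)co1` — 802000 nM

Compound 1 stands at the lowest of the two numbers in this assay; compound 2 sits at the higher one. Among the compounds with values here, the single measured step, a 6.1-fold higher number from compound 1 to compound 2 (0.79 log units; beyond the scatter), is a swap of methyl in place of phenyl on an aromatic carbon, and it shows that the phenyl group carries weight in this assay.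

Compound 3 `COc1ccc(-c2nc(-c3c[nH]c4ccccc34)co2)cc1` differs from compound 1 by methoxy in place of hydrogen on an aromatic carbon. Within the data shown here, no measured step touches this change: the phenyl-to-methyl step says nothing about a substituent on the retained phenyl group, and no other pair is available. The step in this assay from compound 1 to compound 3 is therefore expected to stay within the scatter, with a 1.3-fold lower number from compound 1 to compound 3 (0.12 log units; within the scatter). Compound 3 is expected to give 100000 nM, estimated between 40000 nM and 300000 nM.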

Compound 3, half-maximal inhibitory concentration: 43800 nM
Estimate against measurement, compound 3: 2.3-fold (0.36 log units) above; low and high end bracket the measured number.
By their numbers in this assay, from the lowest: compound 3; then compound 1; then compound 2.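

In this assay, methoxy in place of hydrogen on an aromatic carbon, para to a large group, comes with a 3.0-fold lower number from compound 1 to compound 3 (0.48 log units; beyond the scatter) and so moves the number beyond the scatter in the direction of stronger inhibition. The earlier step, a 6.1-fold higher number from compound 1 to compound 2 (0.79 log units; beyond the scatter), covered only the loss of the whole phenyl group, whereas this result shows that a substituent on the retained phenyl group also changes the number. No measurement bears on why the methoxy group has this effect.

On these data alone, it remains open whether this shift is specific to methoxy or would also appear with a hydroxyl group, a chlorine atom or an amine on the same carbon. Also open, as far as these compounds go, is whether a longer chain, such as ethoxy, would extend or reverse the step.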